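From 1,3-thiazol-2-yl to 4-fluorophenyl: an expected inhibition value

The compounds below may be only part of what the source reports. "The series", "measured", "known", "first", "only" and "open" are said of these compounds alone.

Measured in an assay on isolated protein for inhibition of long-chain fatty acid transport protein 1 (Mus musculus), read by scintillation counting, with a stated time of 20 min; a higher number here means a weaker inhibitor, a lower number a stronger inhibitor:
Compound 1 `O=C(CN1CCN(c2ccccn2)CC1)Nc1nc2c(s1)CCCC2` gives 4900 nM.
Compound 2 `O=C(CN1CCN(c2nccs2)CC1)Nc1nc2c(s1)CCCC2` gives 7900 nM.

Compound 2 holds the higher of the two numbers, but the step of a 1.6-fold higher number from compound 1 to compound 2 (0.21 log units; within the scatter) lies within the scatter, so the two cannot be told apart in this assay. Compound 3 `O=C(CN1CCN(c2ccc(F)cc2)CC1)Nc1nc2c(s1)CCCC2` differs from compound 2 by 4-fluorophenyl in place of 1,3-thiazol-2-yl on an amine nitrogen in a ring. Among the measured compounds shown here, the only measured step at this position was a 1.6-fold higher number from compound 1 to compound 2 (0.21 log units; within the scatter), within the scatter, so no shift beyond the scatter is expected, a 1.3-fold lower number from compound 2 to compound 3 (0.12 log units; within the scatter). Compound 3 is therefore estimated at 6000 nM, with a range from 2000 nM to 20000 nM.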

Compound 3, half-maximal inhibitory concentration: 4000 nM
Estimate against measurement, compound 3: 1.5-fold (0.18 log units) above; the range from low to high includes it.
By their numbers in this assay, from the lowest: compounds 3, 1 and 2 (each within the scatter of the next).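

In this assay a carbon-only ring at this position gives a number that cannot be told apart from those of the rings with hetero atoms: a 2.0-fold lower number from compound 2 to compound 3 (0.30 log units; within the scatter) and a 1.2-fold lower number from compound 1 to compound 3 (0.09 log units; within the scatter) both lie within the scatter. On this amine nitrogen, then, a five-membered aromatic ring and two six-membered ones all read alike. Nothing measured here bears on why this is so.

Still open, from the compounds shown here alone, is whether a group without an aromatic ring on this nitrogen, such as a cyclohexyl ring, a methyl or a short chain ending in an amine, would move the number beyond the scatter.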